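Chain length and an isothiocyanate amide in lung cancer cells

A few compounds are considered here, and "the series" means these few. Any claim that something is new, unique, unknown or untested is made for them only; others in the source may bear on it.

Compound 1 `CN(C)C(=O)c1cc2cnc(Nc3ccc(C(=O)NCCCCCCN=C=S)cc3)nc2n1C1CCCC1` gives 49.4% in a functional assay on NCI-H1299 cells (Homo sapiens) for inhibition, read by CCK-8 assay, with a stated time of 72 h, tested at 1 uM; on this read-out higher numbers stand for a stronger effect at the one concentration tested and lower numbers for a weaker effect. Compound 2 `CN(C)C(=O)c1cc2cnc(Nc3ccc(C(=O)NCCCCCCCN=C=S)cc3)nc2n1C1CCCC1` gives 75.7%. Compound 3 `CN(C)C(=O)c1cc2cnc(Nc3ccc(NC(=O)CCCCCN=C=S)cc3)nc2n1C1CCCC1` gives 34.3%.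

The cores of compound 1 and compound 3 differ in the way counted here: a group of 11 heavy atoms (7 carbon, 2 nitrogen, 1 oxygen, 1 sulfur; no ring) in place of a group of 12 heavy atoms (8 carbon, 2 nitrogen, 1 oxygen, 1 sulfur; no ring), on an aromatic carbon. Going from compound 1 to compound 2 changes (a group of 4 heavy atoms (2 carbon, 1 nitrogen, 1 sulfur; no ring) in place of a group of 3 heavy atoms (1 carbon, 1 nitrogen, 1 sulfur; no ring), on a saturated chain carbon, six bonds along the chain from an amide-type nitrogen), and a number 26.3 percentage points higher from compound 1 to compound 2 (beyond the scatter). Compound 4 `CN(C)C(=O)c1cc2cnc(Nc3ccc(NC(=O)CCCCCCN=C=S)cc3)nc2n1C1CCCC1` carries the same kind of change on the core of compound 3: a group of 4 heavy atoms (2 carbon, 1 nitrogen, 1 sulfur; no ring) in place of a group of 3 heavy atoms (1 carbon, 1 nitrogen, 1 sulfur; no ring), on a saturated chain carbon, five bonds along the chain from a carbonyl carbon. The surroundings are not identical, since in compound 2 the change sits six bonds along the chain from an amide-type nitrogen, while in compound 4 it sits five bonds along the chain from a carbonyl carbon. Because a number 26.3 percentage points higher from compound 1 to compound 2 (beyond the scatter), a step of similar direction, a number 20.7 percentage points higher from compound 3 to compound 4 (beyond the scatter), is expected for compound 4, though it rests on one example. Compound 4 is estimated at 55%, between 35% and 75%.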

Compound 4, a percentage reported as inhibition, at one concentration (the size of the read-out at that concentration, not a potency): 50.9%
The estimate for compound 4 lay 4.1 percentage points above the measured number, within the range that was stated.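

In this assay, the change to the longer isothiocyanate chain gives a number 16.6 percentage points higher from compound 3 to compound 4 (beyond the scatter), so it points the same way on the second core as on the first, and the two steps agree in size: the same change on two cores in this assay, a number 26.3 percentage points higher (beyond the scatter) from compound 1 to compound 2 and a number 16.6 percentage points higher (beyond the scatter) from compound 3 to compound 4, 9.7 percentage points apart, within the scatter of two such steps

This suggests that the change carries across these two cores, but a single pair of steps cannot show that it would hold on a third core, and it does not explain why the number rises. The last step, which turns the amide around, shows no separable difference: a number 1.5 percentage points higher from compound 1 to compound 4 (within the scatter).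

On these data alone, it remains open whether a still longer chain would go on raising the number. As far as these compounds go, it is also open whether an amine or a carboxylic acid in place of the isothiocyanate would keep the effect.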